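Two weak compounds and an untested change

The source may report more compounds than this note shows. Statements on the series, on what has been measured and on what is new or still open speak of the compounds shown alone.

Compound 1 `O=C1C(Nc2ccccc2)=CC(=O)c2c1nc1n2[C@H]2OC[C@@H](O)[C@H]2OC1`: > 8000 nM
Compound 2 `O=C1C=C(N2CCC2)C(=O)c2c1nc1n2[C@H]2OC[C@@H](O)[C@H]2OC1`: > 16000 nM

Both compounds were tested in a functional assay on HeLa cells (Homo sapiens) for inhibition, read by sulforhodamine B assay; a higher number here means a weaker inhibitor, a lower number a stronger inhibitor. In this assay compound 2 gives > 16000 nM, which is a limit and not a measured number, so its true standing is not known. Compound 1 gives > 8000 nM, and this too is a limit.

Compound 3 `COc1ccccc1NC1=CC(=O)c2nc3n(c2C1=O)[C@H]1OC[C@@H](O)[C@H]1OC3` has not yet been measured. It carries (2-methoxyphenyl)amino in place of azetidin-1-yl on a double-bonded ring carbon. Within the data shown here, no step between measured compounds is available to size this change. The expectation therefore rests on compound 1 at > 8000 nM, and little change is foreseen. The estimated step of an at least 1.3-fold lower number from compound 2 to compound 3 (0.12 log units; that floor lies within the scatter) is expected to stay within the scatter. For compound 3 the expected value is 12000 nM, with an estimated range from 4000 nM to 32000 nM.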

Compound 3, half-maximal inhibitory concentration: 2950 nM
The estimate for compound 3 lay 4.1-fold (0.61 log units) above the measured number, outside the stated range (below it).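

In this assay, among these compounds, putting (2-methoxyphenyl)amino in place of azetidin-1-yl on this double-bonded ring carbon gives an at least 5.4-fold lower number from compound 2 to compound 3 (0.73 log units; beyond the scatter), which shows that the activity responds to the group at this position, something the earlier compounds could not show. Among the compounds shown here, compound 3 is also the first compound here with a measured number rather than a limit. The full size of the step remains unknown because its starting point is only a limit: the limit of > 16000 nM in this assay, at which 1 of the 3 values shown sits.

The change brings in the methoxy, the aromatic ring and the amino hydrogen together, so the compounds shown do not tell which of these parts accounts for the step. A simple open-chain amine such as dimethylamino, or a morpholine, on the same carbon would help to separate these contributions.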